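A few compounds are considered here, and "the series" means these few. Any claim that something is new, unique, unknown or untested is made for them only; others in the source may bear on it.

Measured compounds:
compound 1 `CCOC(=O)c1cn(C(c2ccccc2)c2cc3cc(Br)ccc3nc2OC)nn1` — 16.1%
compound 2 `CCCc1cn(C(c2ccccc2)c2cc3cc(Br)ccc3nc2OC)nn1` — 8.3%
compound 3 `COc1nc2ccc(Br)cc2cc1C(c1ccccc1)n1cc(-c2ccc(OC(F)(F)F)cc2)nn1` — 21.6%

In an ADME assay on PC-3 cells (Homo sapiens) for cytotoxicity, read by sulforhodamine B assay, with a stated time of 48 h, tested at 10 uM (on this read-out lower numbers stand for less inhibition and higher numbers for more inhibition at the one concentration tested (going by the name of the read-out)), compound 1 gives 16.1%. Of the three numbers this is the second highest, yet neither neighbour is separated from it by more than the scatter: the step of a number 5.5 percentage points higher from compound 1 to compound 3 (within the scatter) and the step of a number 7.8 percentage points lower from compound 1 to compound 2 (within the scatter) both remain inside the usual spread of repeat measurements. Among the measured compounds shown here, only the step of a number 13.3 percentage points higher from compound 2 to compound 3 (beyond the scatter) is beyond the scatter, and it is modest.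

The next compound, compound 4 `COc1nc2ccc(Br)cc2cc1C(c1ccccc1)n1cc(-c2cccc(F)c2)nn1`, differs from compound 1 in one place: 3-fluorophenyl in place of ethoxycarbonyl on an aromatic carbon.

For the measured compounds named here, two measured steps bear on this change. The step of a number 5.5 percentage points higher from compound 1 to compound 3 (within the scatter) exchanges the same ethoxycarbonyl for a different aryl group on the same aromatic carbon and stays within the scatter. The step of a number 13.3 percentage points higher from compound 2 to compound 3 (beyond the scatter) shows that an aryl group at this carbon can sit modestly above an alkyl chain. Taken together, a small rise or no change beyond the scatter is expected in this assay for compound 4.

On that basis compound 4 is estimated at 20%, within the range 11% to 30%, which means an expected step of a number 3.9 percentage points higher from compound 1 to compound 4 (within the scatter).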

Compound 4, a percentage reported as inhibition, at one concentration (the size of the read-out at that concentration, not a potency): 14.6%
Compound 4: the middle estimate sits 5.4 percentage points above what was measured; measured number inside the range.
By their numbers in this assay, from the lowest: compounds 2, 4, 1 and 3 (each within the scatter of the next, the first and the last beyond it).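

In the series, replacing ethoxycarbonyl with 3-fluorophenyl on this aromatic carbon of the five-membered aromatic ring with 3 nitrogen adds a six-membered aromatic ring of carbon only and removes the hydrogen-bond acceptors, yet the number stays within the scatter in this assay (a number 1.5 percentage points lower from compound 1 to compound 4 (within the scatter)). The two aryl compounds also remain within the scatter of each other (a number 7 percentage points lower from compound 3 to compound 4 (within the scatter)), and 3-fluorophenyl does not separate from propyl (a number 6.3 percentage points higher from compound 2 to compound 4 (within the scatter)), so an aryl group at this carbon does not by itself reproduce the one step beyond the scatter among these four compounds (a number 13.3 percentage points higher from compound 2 to compound 3 (beyond the scatter)). No available measurement accounts for these numbers.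

The compounds shown leave open whether unsubstituted phenyl, a primary amine, a carboxylic acid or a longer alkyl chain on this carbon would stand beyond the scatter from the values seen so far. They also leave open how this aromatic carbon responds when the bromine or methoxy on the shared core is replaced by another group, since both stay the same throughout.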